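Swapping Chloro for Bromo in Two Related Inhibitors

The compounds below may be only part of what the source reports. "The series", "measured", "known", "first", "only" and "open" are said of these compounds alone.

Compound 1 `O=C(CSc1nc(Nc2ccccc2)c2ccccc2n1)Nc1cccc(Cl)c1` and compound 2 `O=C(CSc1nc(Nc2ccccc2)c2ccccc2n1)Nc1cccc(Br)c1` share one core and differ in a single place: bromo in place of chloro on an aromatic carbon. In a functional assay on MGC-803 cells (Homo sapiens) for inhibition, read by MTT assay, with a stated time of 72 h (a higher number here means a weaker inhibitor, a lower number a stronger inhibitor), compound 1 gives 14300 nM, and compound 2 gives 9620 nM; the step is a 1.5-fold lower number from compound 1 to compound 2 (0.17 log units; within the scatter). Compound 3 `C=CC(=O)Nc1cccc(NC(=O)CSc2nc(Nc3ccccc3Cl)c3ccccc3n2)c1` rests on a different core, and the difference between the two cores is not broken down here. In this assay compound 3 gives 20700 nM. Compound 4 `C=CC(=O)Nc1cccc(NC(=O)CSc2nc(Nc3ccccc3Br)c3ccccc3n2)c1` has not been measured; from compound 3 it differs by bromo in place of chloro on an aromatic carbon. This is the same kind of change as that from compound 1 to compound 2, though there the place was meta to a large group and here it is ortho to a large group. Because the earlier step of a 1.5-fold lower number from compound 1 to compound 2 (0.17 log units; within the scatter) stayed within the scatter, a similarly small step is expected a 1.4-fold lower number from compound 3 to compound 4 (0.14 log units; within the scatter). Compound 4 is therefore estimated at 15000 nM, with a likely range from 7000 nM to 35000 nM.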

Compound 4, half-maximal inhibitory concentration: 12800 nM
The estimate for compound 4 lay 1.2-fold (0.07 log units) above the measured number, within the range that was stated.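

In this assay the swap of chloro for bromo gives a 1.6-fold lower number from compound 3 to compound 4 (0.21 log units; within the scatter) on this core, and the step matches the one seen on the other core: the same change on two cores in this assay, a 1.5-fold lower number (0.17 log units; within the scatter) from compound 1 to compound 2 and a 1.6-fold lower number (0.21 log units; within the scatter) from compound 3 to compound 4, 1.1-fold (0.04 log units) apart, within the scatter of two such steps. So, in these two pairs, the change carries from one core to the other as a similarly small step. It does not show that bromo truly gives a stronger inhibitor than chloro, since neither step rises above the scatter, and two pairs cannot speak for other cores.

The compounds shown leave open what a different group would do in the place of the halogen, such as a methoxy group or an amine. They also leave open whether fluoro or iodo would follow the same pattern.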